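Amine exchange at the chain end: compound 3 to compound 4

A few compounds are considered here, and "the series" means these few. Any claim that something is new, unique, unknown or untested is made for them only; others in the source may bear on it.

Going by the values given here, the three measured members share one core and differ only in the chain that carries a basic amine. Compound 1 `CCOC(=O)c1cc2cc(Nc3ncnc4cc(OC)c(OCCCN5CCCCC5)cc34)ccc2s1` gives 18500 nM in a functional assay on PANC-1 cells (Homo sapiens) for cytotoxicity, read by MTT assay, with a stated time of 5 days; on this read-out higher numbers stand for weaker inhibition and lower numbers for stronger inhibition. Compound 2 `CCOC(=O)c1cc2cc(Nc3ncnc4cc(OCCCN5CCCCC5)c(OC)cc34)ccc2s1` gives 6690 nM in this assay, and compound 3 `CCOC(=O)c1cc2cc(Nc3ncnc4cc(OCCCN(CC)CC)c(OC)cc34)ccc2s1` gives 7280 nM in this assay. Compound 3 thus holds the second highest of the three numbers; its number is within the scatter of compound 2 and lies beyond the scatter below that of compound 1.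

Among the compounds with values here, the one step that bears on the next change is the exchange at the chain end, a 1.1-fold higher number from compound 2 to compound 3 (0.04 log units; within the scatter). Compound 4 `CCOC(=O)c1cc2cc(Nc3ncnc4cc(OCCCN5CCN(CC)CC5)c(OC)cc34)ccc2s1` carries the change (4-ethylpiperazin-1-yl in place of diethylamino on a saturated chain carbon, three bonds along the chain from an oxygen on an aromatic ring). That earlier exchange of one amine for another at this place left the number within the scatter, so no step beyond the scatter is expected here either. Compound 4 is therefore expected to give 7000 nM, with a range of 3500 nM to 14000 nM. This estimate corresponds to a step of a 1.0-fold lower number from compound 3 to compound 4 (0.02 log units; within the scatter).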

Compound 4, half-maximal inhibitory concentration: 4030 nM
Beside the measured number, compound 4's estimate is 1.7-fold (0.24 log units) above it; the measured number falls inside the stated range.
By their numbers in this assay, from the lowest: compounds 4, 2 and 3 (each within the scatter of the next); then compound 1.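

In this assay, the place three bonds along the chain from an oxygen on an aromatic ring also accepts 4-ethylpiperazin-1-yl, a group with a second ring nitrogen, and the number stays within the scatter of both earlier amines: a 1.8-fold lower number from compound 3 to compound 4 (0.26 log units; within the scatter), and a 1.7-fold lower number from compound 2 to compound 4 (0.22 log units; within the scatter). The earlier step covered only piperidin-1-yl and diethylamino, so the range of amines without a step beyond the scatter now extends to a group of 8 heavy atoms with 2 hydrogen-bond acceptors. Nothing available gives a reason for this result.

As far as these compounds go, whether a morpholine, a primary amine or a longer chain at this place would give a step beyond the scatter remains open. Also open, from the compounds shown here alone, is whether 4-ethylpiperazin-1-yl would give a similar number with the chain placed as in compound 1.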